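The compounds below may be only part of what the source reports. "The series", "measured", "known", "first", "only" and "open" are said of these compounds alone.

In a functional assay on K562 cells (Homo sapiens) for antiproliferative activity, read by MTT assay, with a stated time of 5 days (a higher number here means a weaker inhibitor, a lower number a stronger inhibitor), compound 1 (`COc1ccc(/C=C(/C(=O)c2cc(OC)c(OC)c(OC)c2)c2ccccc2O)cc1O`) gives 49000 nM. Compound 3 (`COc1ccc(C=C(C(=O)c2cc(OC)c(OC)c(OC)c2)c2ccccc2O)cc1O`), the same structure with the double bond drawn without a configuration, gives 35000 nM, level with compound 1 within the scatter. Compound 2 (`COc1ccc(/C=C(/C(=O)c2cc(OC)c(OC)c(OC)c2)c2ccc(N(C)C)cc2)cc1`) gives 150000 nM, so compound 1 lies clearly lower than compound 2.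

Compound 4 (`COc1ccc(/C=C(/C(=O)c2cc(OC)c(OC)c(OC)c2)c2ccccc2O)cc1F`) differs from compound 1 by fluoro in place of hydroxy on an aromatic carbon, turning 3-hydroxy-4-methoxyphenyl into 3-fluoro-4-methoxyphenyl. Among the compounds with values here, the only measured step is a 1.4-fold lower number from compound 1 to compound 3 (0.15 log units; within the scatter), and it reflects (the fact that one of compounds 1 and 3 is drawn with a defined configuration and the other without, at the place where they differ). It leaves the substituents untouched and so bears only loosely on this change. Within the data shown here, no measured step covers fluoro in place of hydroxy, which leaves no basis for a direction. No step beyond the scatter is expected in this assay, and the value of compound 1 at 49000 nM serves as the anchor. The expected change is a 1.1-fold lower number from compound 1 to compound 4 (0.04 log units; within the scatter). Compound 4 is estimated at 45000 nM, with an expected range from 15000 nM to 130000 nM.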

Compound 4, half-maximal inhibitory concentration: 60000 nM
Compound 4: the middle estimate sits 1.3-fold (0.12 log units) below what was measured; the measured number falls inside the stated range.
By their numbers in this assay, from the lowest: compounds 3, 1 and 4 (each within the scatter of the next); then compound 2.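

Fluoro in place of hydroxy on this aromatic carbon gives a 1.2-fold higher number from compound 1 to compound 4 (0.09 log units; within the scatter) in this assay, the first reading of a substituent change at this position, as the earlier step concerned only how the double bond is drawn. The hydroxy can therefore be exchanged for fluoro, with hydrogen-bond donors and acceptors on the group going from 1 each to 0, without a step beyond the scatter, at least in this pair on the core of compound 1. Nothing measured on record bears on why this exchange behaves as it does.

Still open, from the compounds shown here alone, is whether an amine or a carboxylic acid on this carbon would move the number beyond the scatter. Compound 2 differs from compound 1 in more than one place, so the hydroxy on the other aromatic ring also remains unresolved on its own.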